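A few compounds are considered here, and "the series" means these few. Any claim that something is new, unique, unknown or untested is made for them only; others in the source may bear on it.

Measured compounds:
- compound 1 `C=C1C(=O)O[C@@H]2CC(C)=C([C@@H](C)CCCOC(C)=O)[C@@H](OC(=O)CN3CCCCC3)[C@H]12`: 10300 nM
- compound 2 `C=C1C(=O)O[C@@H]2CC(C)=C([C@@H](C)CCCOC(C)=O)[C@@H](OC(=O)COc3ccc(C(C)=O)cc3)[C@H]12`: 43900 nM
- compound 3 `C=C1C(=O)O[C@@H]2CC(C)=C([C@@H](C)CCCOC(C)=O)[C@@H](OC(=O)c3ccccc3F)[C@H]12`: 17000 nM

In a functional assay on HeLa cells (Homo sapiens) for cytotoxicity, read by sulforhodamine B assay, with a stated time of 72 h (on this read-out higher numbers stand for weaker inhibition and lower numbers for stronger inhibition), compound 1 gives 10300 nM, the lowest of the three numbers. Compound 3 sits nearest, with a 1.7-fold higher number from compound 1 to compound 3 (0.22 log units; within the scatter), while compound 2 lies furthest away, with a 4.3-fold higher number from compound 1 to compound 2 (0.63 log units; beyond the scatter). Between the other two the step is a 2.6-fold lower number from compound 2 to compound 3 (0.41 log units; beyond the scatter).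

Compound 4 `C=C1C(=O)O[C@@H]2CC(C)=C([C@@H](C)CCCOC(C)=O)[C@@H](OC(=O)c3cc(OC)c(OC)c(OC)c3)[C@H]12` has not yet been measured in this assay. It differs from compound 1 at one place: 3,4,5-trimethoxyphenyl in place of (piperidin-1-yl)methyl on a carbonyl carbon.

Among the compounds with values here, two measured steps bear on this change. The step from compound 1 to compound 3 also puts an aromatic group on the carbonyl carbon in place of (piperidin-1-yl)methyl, and it stayed within the scatter. The step from compound 2 to compound 3 shows that an aromatic group directly on the carbonyl carbon gave a modestly lower number than a chain-linked aromatic group. Neither step suggests a large move from compound 1. The expected step is therefore a 1.4-fold higher number from compound 1 to compound 4 (0.13 log units; within the scatter), a small rise that may well remain within the scatter.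

Compound 4 is estimated to give 14000 nM in this assay, with a range from 6000 nM to 40000 nM.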

Compound 4, half-maximal inhibitory concentration: 6540 nM
Beside the measured number, compound 4's estimate is 2.1-fold (0.33 log units) above it; low and high end bracket the measured number.
By their numbers in this assay, from the lowest: compounds 4, 1 and 3 (each within the scatter of the next, the first and the last beyond it); then compound 2.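

In this assay, the step to 3,4,5-trimethoxyphenyl on the carbonyl carbon is a 1.6-fold lower number from compound 1 to compound 4 (0.20 log units; within the scatter), so this aromatic group, which has no nitrogen and no (piperidin-1-yl)methyl chain, cannot be told apart from the group in compound 1. Within the data shown here, what the earlier compounds could not show is that the substituents on an aromatic ring held directly on this carbonyl carbon can shift the number: two such rings now differ by a 2.6-fold lower number from compound 3 to compound 4 (0.41 log units; beyond the scatter), a modest step beyond the scatter. The step to the chain-linked aromatic group is larger, at a 6.7-fold lower number from compound 2 to compound 4 (0.83 log units; beyond the scatter), which leaves compound 2 with the highest number of the four, since its steps to compound 1, compound 3 and compound 4 are all beyond the scatter. Nothing available here explains any of these differences.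

The compounds shown do not tell whether the step from compound 3 to compound 4 comes from gaining the methoxy groups or from losing the fluorine, which a plain phenyl group or a 4-methoxyphenyl group on the same carbonyl carbon would help to separate. From the compounds shown here alone, it also remains open how a different amine on the chain, such as morpholin-4-yl in place of piperidin-1-yl, would compare with compound 1.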